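This account rests on a few compounds, and the source may have more. Where it says the series, first, only, none or still open, it means among the compounds named here.

Compound 1 `CC(C)=CCCC1=CC[C@H](C(=O)NCCC(=O)O)[C@@H](c2ccccc2)C1` in an assay on isolated protein for inhibition of Apoptosis regulator Bcl-2 (Homo sapiens), read by fluorescence polarization, with stated times of 5 min and 10 min (on this read-out lower numbers stand for stronger inhibition and higher numbers for weaker inhibition), gives > 23000 nM, a limit of the assay.
Compound 2 `CONC(=O)[C@@H]1CC=C(CCC=C(C)C)C[C@H]1c1ccccc1` in this assay gives 2700 nM.
Compound 3 `CC(C)=CCCC1=CC[C@H](C(=O)Nc2ccc(O)cc2)[C@@H](c2ccccc2)C1` in this assay gives > 23000 nM, a limit of the assay.

Among the three measured compounds, compound 2 is the only one that gives an actual number in this assay; the other two values are limits. Compound 2 carries a methoxy on the amide-type nitrogen of the shared core. Compound 4 `COc1ccc(NC(=O)[C@@H]2CC=C(CCC=C(C)C)C[C@H]2c2ccccc2)cc1` differs from it in one place: 4-methoxyphenyl in place of methoxy on an amide-type nitrogen.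

Only one measured step exists among these compounds, a step that the two limits leave unreadable from compound 1 to compound 3, and its size cannot be read because the limit of > 23000 nM in this assay, at which 2 of the 3 values shown sit, holds both of its values. Among the compounds with values here, no step is recorded from compound 2 to compound 3, so only the two values themselves can be compared. Compound 3 carries a 4-hydroxyphenyl on the same nitrogen and reaches only the limit of the assay. Within the data shown here, compound 2, with methoxy in that place, is the one compound that gives a number.

Since the aryl amide of compound 3 sits at the limit, compound 4, which places a 4-methoxyphenyl on the same nitrogen, is expected to lose potency relative to compound 2, a step of about a 5.6-fold higher number from compound 2 to compound 4 (0.74 log units; beyond the scatter). Compound 4 is estimated at 15000 nM, within a range of 4000 nM to 60000 nM, with a real chance that the assay again reports only a limit.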

Compound 4, inhibition constant: > 23000 nM
Compound 4 gave a limit, no number; the forecaster's own chance of this, stated with the estimate: 55%; at least 1.5-fold (0.18 log units) between middle value and limit.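

Within the data shown here, the change of methoxy to 4-methoxyphenyl on the amide-type nitrogen gives an at least 8.5-fold higher number from compound 2 to compound 4 (0.93 log units; beyond the scatter), the first step at this position whose size can be read, and it lies beyond the scatter in this assay. Among these compounds, the earlier step from compound 1 to compound 3 could not be read, so the earlier compounds gave no measure of what a change on this nitrogen costs, whereas this step sets a lower bound, since its upper end is a limit and not a number. Compound 2, with methoxy, now stands as the only compound on this nitrogen that gives a number, while the 4-methoxyphenyl of compound 4 joins the 4-hydroxyphenyl of compound 3 and the 2-carboxyethyl of compound 1 at the same limit: the limit of > 23000 nM in this assay, at which 3 of the 4 values shown sit.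

From the compounds shown here alone, how far compound 1, compound 3 and compound 4 each lie past that limit remains open, so no order among them can be given. Also open, going by these compounds, is whether a hydroxy, an ethoxy or an unsubstituted phenyl on the same nitrogen would give a number, and so whether the loss follows from the aromatic ring or from the larger group as a whole.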